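The source may report more compounds than this note shows. Statements on the series, on what has been measured and on what is new or still open speak of the compounds shown alone.

- Compound 1 (`CC[C@H](C)[C@@H](O)C(=O)O[C@@H](C(=O)O[C@@H](C(=O)O[C@@H](C(=O)O[C@@H](C(=O)OC[C@@H](O)[C@@H](O)[C@H](O)CO)[C@@H](C)CC)[C@@H](C)CC)[C@@H](C)CC)[C@@H](C)CC`) gives 15600 nM
- Compound 2 (`CC[C@H](C)[C@@H](O)C(=O)O[C@@H](C(=O)O[C@@H](C(=O)O[C@@H](C(=O)O[C@@H](C(=O)OC[C@@H](O)[C@@H](O)CO)[C@@H](C)CC)[C@@H](C)CC)[C@@H](C)CC)[C@@H](C)CC`) gives 11100 nM

In a functional assay on MCF7 cells (Homo sapiens) for cytotoxicity, read by MTT assay, with a stated time of 24 h (a lower number here means a stronger inhibitor, a higher number a weaker inhibitor), compound 2 gives 11100 nM, which lies within the usual scatter of compound 1 at 15600 nM. Compared with compound 2, compound 3 (`CC[C@H](C)[C@@H](O)C(=O)O[C@@H](C(=O)O[C@@H](C(=O)O[C@@H](C(=O)O[C@@H](C(=O)O[C@@H]([C@H](O)[C@H](O)CO)[C@H](O)CO)[C@@H](C)CC)[C@@H](C)CC)[C@@H](C)CC)[C@@H](C)CC`) carries 1-(1,2-dihydroxyethyl)-2,3,4-trihydroxybutyl in place of 2,3,4-trihydroxybutyl on an oxygen next to a carbonyl group. Among the measured compounds shown here, only one measured step bears on this: hydrogen in place of hydroxymethyl on the same chain, with a 1.4-fold lower number from compound 1 to compound 2 (0.15 log units; within the scatter). One step is thin evidence, but the expected change is a 1.3-fold higher number from compound 2 to compound 3 (0.10 log units; within the scatter), nothing beyond the scatter in either direction. For compound 3 the estimated value is 14000 nM, with an expected range from 7000 nM to 28000 nM.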

Compound 3, half-maximal inhibitory concentration: 27800 nM
Beside the measured number, compound 3's estimate is 2.0-fold (0.30 log units) below it, within the range that was stated.
By their numbers in this assay, from the lowest: compounds 2, 1 and 3 (each within the scatter of the next, the first and the last beyond it).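

In this assay, among the compounds shown here, 1-(1,2-dihydroxyethyl)-2,3,4-trihydroxybutyl in place of 2,3,4-trihydroxybutyl on an oxygen next to a carbonyl group gives a 2.5-fold higher number from compound 2 to compound 3 (0.40 log units; beyond the scatter) and is the first change here to pass the scatter. In place of 2,3,4,5-tetrahydroxypentyl, the same group gives a 1.8-fold higher number from compound 1 to compound 3 (0.25 log units; within the scatter) and stays within it, so compound 3 stands apart only from compound 2. Nothing shown here explains this difference. Open, on these data alone, is whether an amine, a carboxylic acid or a plain butyl chain in this place would shift the number further.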